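A few compounds are considered here, and "the series" means these few. Any claim that something is new, unique, unknown or untested is made for them only; others in the source may bear on it.

In a functional assay on PC-3 cells (Homo sapiens) for antiproliferative activity, read by MTT assay, with a stated time of 48 h (on this read-out lower numbers stand for stronger inhibition and higher numbers for weaker inhibition), compound 1 `COc1ccc(CN(C(=O)CSc2nc3ccccc3s2)c2cc(OC)c(OC)c(OC)c2)cc1` gives 8460 nM, and compound 2 `COc1ccc(CN(C(=O)CSc2nc3ccccc3s2)c2cc(OC)c(OC)c(OC)c2)cc1[N+](=O)[O-]` gives 26500 nM. Compound 3 `COc1cc(N(Cc2ccc(Cl)cc2)C(=O)CSc2nc3ccccc3s2)cc(OC)c1OC` reads > 80000 nM, which is a limit of the assay and not a number. Compound 4 `COc1cc(N(Cc2ccc(F)cc2)C(=O)CSc2nc3ccccc3s2)cc(OC)c1OC` differs from it by one exchange, fluoro in place of chloro on an aromatic carbon. The closest measured change is chloro in place of methoxy, an at least 9.4-fold higher number from compound 1 to compound 3 (0.97 log units; beyond the scatter). The exchange of the whole benzyl substituent, an at least 3.0-fold higher number from compound 2 to compound 3 (0.47 log units; beyond the scatter), points the same way, and the nitro change, a 3.1-fold higher number from compound 1 to compound 2 (0.50 log units; beyond the scatter), is modest. None of these tests fluoro directly, so only a modest move to a lower number is expected in this assay, and a result still at the limit would not surprise. The estimated change is an at least 1.7-fold lower number from compound 3 to compound 4 (0.24 log units; that floor lies within the scatter). For compound 4 the expected value is 45000 nM, with an estimated range of 15000 nM to 100000 nM.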

Compound 4, half-maximal inhibitory concentration: 50800 nM
Compound 4: middle estimate off by 1.1-fold (0.05 log units), on the low side; the measured number falls inside the stated range.
By their numbers in this assay, from the lowest: compound 1; then compounds 2 and 4 (each within the scatter of the next). At a limit, above all of these: compound 3.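

Compound 3 stands at > 80000 nM in this assay, which is a limit of the assay and not a number. Fluoro at the same place gives a readable value, with an at least 1.5-fold lower number from compound 3 to compound 4 (0.19 log units; that floor lies within the scatter), so the floor of this exchange does not clear the scatter. Against methoxy at this place, fluoro still gives a weaker result, with a 6.0-fold higher number from compound 1 to compound 4 (0.78 log units; beyond the scatter), whereas a 1.9-fold higher number from compound 2 to compound 4 (0.28 log units; within the scatter) separates nothing.

Going by these compounds, it remains open whether plain hydrogen, an amine or a hydroxyl at this place would match methoxy. On these data alone, it is also open whether a longer ethoxy group would go lower still.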